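Methyl for methoxy on the aryl ring of compound 3

A few compounds are considered here, and "the series" means these few. Any claim that something is new, unique, unknown or untested is made for them only; others in the source may bear on it.

Measured so far:
- compound 1 `COc1ccc(C2=NO[C@@H]3[C@H](CO)C[C@H](CO)[C@H]23)cc1OC`: > 50 ug/mL (a limit)
- compound 2 `OC[C@@H]1C[C@H](CO)[C@@H]2C(c3ccc(Cl)cc3)=NO[C@H]12`: 22.9 ug/mL
- compound 3 `COc1ccc(C2=NO[C@@H]3[C@H](CO)C[C@H](CO)[C@H]23)cc1`: > 50 ug/mL (a limit)

In a functional assay on HT-29 cells (Homo sapiens) for cytotoxicity, read by MTT assay, with a stated time of 48 h (a higher number here means a weaker inhibitor, a lower number a stronger inhibitor), compound 3 gives > 50 ug/mL, which is a limit of the assay rather than a number. Compound 1 gives > 50 ug/mL, also a limit. Among the measured compounds shown here, compound 2 gives 22.9 ug/mL and is the only compound of the three with a numeric value.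

Compound 4 `Cc1ccc(C2=NO[C@@H]3[C@H](CO)C[C@H](CO)[C@H]23)cc1` differs from compound 3 by methyl in place of methoxy on an aromatic carbon.

For the measured compounds named here, two measured steps bear on this change. The step of an at least 2.1-fold higher number from compound 2 to compound 3 (0.33 log units; beyond the scatter) shows that replacing chloro with methoxy weakens inhibition by at least a modest amount. The step that the two limits leave unreadable from compound 1 to compound 3 is unreadable, as both values sit at the limit of > 50 ug/mL in this assay, at which 2 of the 3 values shown sit.

Methyl in place of methoxy is a smaller change than either measured step, and no measured compound carries methyl. Compound 4 is therefore expected to stay close to where compound 3 stands, with the step of an at least 1.1-fold lower number from compound 3 to compound 4 (0.04 log units; that floor lies within the scatter) in this assay estimated as small or none beyond the scatter. The estimate for compound 4 in this assay is 45 ug/mL, within 20 ug/mL to 80 ug/mL, with a real chance that only a limit is reported.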

Compound 4, half-maximal inhibitory concentration: > 50 ug/mL
Compound 4 was reported as a limit; the forecaster's own chance of this, stated with the estimate: 55%; at least 1.1-fold (0.04 log units) between middle value and limit.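

In this assay, methyl in place of chloro on the aromatic carbon para to a large group gives an at least 2.1-fold higher number from compound 2 to compound 4 (0.33 log units; beyond the scatter), the same outcome at this position as with methoxy. Methoxy and methyl therefore both fail to match chloro here, even though methyl carries no oxygen, and compound 2 remains the only one of the four compounds with a numeric value. The steps from compound 1 to compound 3 and from compound 3 to compound 4 cannot be read, so no order can be set among the compounds at the limit: the limit of > 50 ug/mL in this assay, at which 3 of the 4 values shown sit.

From the compounds shown here alone, whether the numeric value in compound 2 is particular to chloro remains open, and bromo or an amine at the same position would bear on that. How far compound 2 itself can be improved also remains open, as the compounds shown differ only on the aromatic ring.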